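A few compounds are considered here, and "the series" means these few. Any claim that something is new, unique, unknown or untested is made for them only; others in the source may bear on it.

Compound 1 `O=C1NCCC12CCN(c1c(Cl)cncc1-c1cc[nH]c1)CC2` holds the highest number of the two measured in a functional assay on MV4-11 cells (Homo sapiens) for inhibition, read by resazurin assay, with a stated time of 72 h (on this read-out higher numbers stand for weaker inhibition of growth and lower numbers for stronger inhibition of growth), where compound 1 gives 1050 nM. Its nearest neighbour, compound 2 `O=C1NCCC12CCN(c1c(Cl)cncc1-c1ccc(-c3ccccc3)s1)CC2`, gives 960 nM in this assay, a gap within the scatter despite quite different groups at that place. Compound 3 `Cn1cccc1-c1cncc(Cl)c1N1CCC2(CCNC2=O)CC1` has not been measured; it differs from compound 1 by 1-methyl-1H-pyrrol-2-yl in place of 1H-pyrrol-3-yl on an aromatic carbon. Within the data shown here, no measured pair shows this change, so its direction is open. Given how little compound 1 and compound 2 differ, the step of a 1.1-fold higher number from compound 1 to compound 3 (0.06 log units; within the scatter) is expected to be none beyond the scatter. Compound 3 is estimated at 1200 nM, with a range from 400 nM to 4000 nM.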

Compound 3, concentration for 50% growth inhibition: 900 nM
Compound 3: middle estimate off by 1.3-fold (0.12 log units), on the high side; the measured number falls inside the stated range.
By their numbers in this assay, from the lowest: compounds 3, 2 and 1 (each within the scatter of the next).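

In this assay, putting 1-methyl-1H-pyrrol-2-yl in place of 1H-pyrrol-3-yl gives a 1.2-fold lower number from compound 1 to compound 3 (0.07 log units; within the scatter) even though the hydrogen-bond donor of 1H-pyrrol-3-yl is gone and the point of attachment on the five-membered ring differs. At this aromatic carbon, then, the donor of 1H-pyrrol-3-yl is not needed to keep the number within the scatter. No measurement at hand speaks to why this is so. Going by these compounds, whether an amine or a carboxylic acid here would move the number beyond the scatter remains open, and the parts played by the methyl and by the point of attachment are not separated.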